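Aryl exchange at the carbonyl: notes before compound 3

The compounds below may be only part of what the source reports. "The series", "measured", "known", "first", "only" and "open" are said of these compounds alone.

Measured so far:
compound 1 `COc1ccc(-c2cc3ccccc3nc2/C=C/C(=O)c2ccc(O)cc2)cc1`, which in a functional assay on A549 cells (Homo sapiens) for antiproliferative activity, read by XTT assay, with a stated time of 72 h (on this read-out lower numbers stand for stronger inhibition and higher numbers for weaker inhibition), gives 7440 nM
compound 2 `COc1ccc(-c2cc3ccccc3nc2/C=C/C(=O)c2ccco2)cc1`, which in this assay gives 6130 nM

For the measured compounds named here, the only step available, a 1.2-fold lower number from compound 1 to compound 2 (0.08 log units; within the scatter), is an exchange of the aryl group on the carbonyl carbon, and it lies within the scatter, so compound 2 and compound 1 cannot be separated on these numbers; compound 2 simply carries the second of two closely spaced values.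

Compound 3 `COc1ccc(-c2cc3ccccc3nc2/C=C/C(=O)c2ccc(Br)s2)cc1` differs from compound 2 by 5-bromothiophen-2-yl in place of furan-2-yl on a carbonyl carbon. Going by the values given here, the single measured step bears on it directly, being the same kind of exchange at the same carbonyl carbon, and it produced no movement beyond the scatter. On that basis no step beyond the scatter is expected in this assay for this change either, in neither direction.

Compound 3 is therefore expected at about 5000 nM, with a range from 1800 nM to 14000 nM. The expected step is a 1.2-fold lower number from compound 2 to compound 3 (0.09 log units; within the scatter).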

Compound 3, half-maximal inhibitory concentration: 6250 nM
Estimate against measurement, compound 3: 1.3-fold (0.10 log units) below; measured number inside the range.
By their numbers in this assay, from the lowest: compounds 2, 3 and 1 (each within the scatter of the next).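

In this assay, 5-bromothiophen-2-yl in place of furan-2-yl on the carbonyl carbon gives a 1.0-fold higher number from compound 2 to compound 3 (0.01 log units; within the scatter), and the same group in place of 4-hydroxyphenyl gives a 1.2-fold lower number from compound 1 to compound 3 (0.08 log units; within the scatter). For the compounds shown here, the first exchange at this position that brings in sulfur and bromine therefore separates nothing: compound 1, compound 2 and compound 3 cannot be told apart on these numbers, so three different aryl groups on this carbon now share one level rather than two. The data shown offer no explanation for this flat result.

Going by these compounds, it remains open whether a non-aromatic group on the carbonyl carbon, such as a longer alkyl chain, or a phenyl ring carrying an amine or a carboxylic acid, would stand apart from these three. Also open, on these data alone, is whether changes elsewhere on the shared core would produce a step beyond the scatter in this assay.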